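Lengthening the ester chain of compound 1

A few compounds are considered here, and "the series" means these few. Any claim that something is new, unique, unknown or untested is made for them only; others in the source may bear on it.

Compound 1 `C=C[C@@](C)(/C=C/c1ccc(OC(C)=O)cc1)CCC=C(C)C`: 67%
Compound 2 `C=C[C@@](C)(/C=C/c1ccc(OC(=O)CC)cc1)CCC=C(C)C`: 54%
Compound 3 `C=C[C@@](C)(/C=C/c1ccc(OC(=O)CCC)cc1)CCC=C(C)C`: not yet measured

Within the data shown here, in a functional assay on PC-3 cells (Homo sapiens) for inhibition, with a stated time of 48 h, tested at 50 uM (on this read-out lower numbers stand for less inhibition of growth and higher numbers for more inhibition of growth at the one concentration tested), compound 1 gives 67%, the higher of the two numbers so far. Compound 3 differs from it by ethyl in place of hydrogen on a saturated chain carbon bound to a carbonyl carbon. Among the measured compounds shown here, one measured step bears on this, with methyl in place of hydrogen at that same place: a number 13 percentage points lower from compound 1 to compound 2 (beyond the scatter). Ethyl is the larger addition, so a drop of similar or somewhat greater size is expected, though a single step is thin evidence. The expected change is a number 20 percentage points lower from compound 1 to compound 3 (beyond the scatter). In this assay the estimate for compound 3 is 47%, with an expected range of 32% to 62%.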

Compound 3, percent growth inhibition at one concentration: 38%
Estimate against measurement, compound 3: 9 percentage points above; the measured number falls inside the stated range.
By their numbers in this assay, from the lowest: compound 3; then compound 2; then compound 1.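

In this assay the fall does not stop after the first addition: methyl in place of hydrogen on a saturated chain carbon, two bonds along the chain from a carbonyl carbon, brings a number 16 percentage points lower from compound 2 to compound 3 (beyond the scatter) as a further drop. Taken together, ethyl in place of hydrogen at the first chain position gives a number 29 percentage points lower from compound 1 to compound 3 (beyond the scatter) overall, so the number falls with each lengthening across these three esters, and none goes against this. Nothing measured here gives a reason for the fall. From the compounds shown here alone, whether a longer chain such as pentyl continues the trend remains open, as does the effect of a branched isopropyl group or a terminal amine.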